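Compound 1 to compound 4: nitro in place of fluoro

This account rests on a few compounds, and the source may have more. Where it says the series, first, only, none or still open, it means among the compounds named here.

In a functional assay on HL-60 cells (Homo sapiens) for antiproliferative activity, read by MTT assay, with a stated time of 72 h (on this read-out lower numbers stand for stronger inhibition and higher numbers for weaker inhibition), compound 1 (`COc1cc(-c2ncnn2-c2cccc(F)c2)cc(OC)c1OC`) gives > 10000 nM as a limit and not a number. Compound 2 (`COc1cc(-c2ncnn2-c2ccc(Cl)cc2Cl)cc(OC)c1OC`) gives > 10000 nM as a limit as well. Compound 3 (`COc1cc(-c2ncnn2-c2ccc(Cl)cc2)cc(OC)c1OC`) gives > 10000 nM as a limit too. All three values are this same limit (the limit of > 10000 nM in this assay, at which 3 of the 3 values shown sit), so compound 1 has no number to place it within the series.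

Compound 4 (`COc1cc(-c2ncnn2-c2cccc([N+](=O)[O-])c2)cc(OC)c1OC`) carries nitro in place of fluoro on an aromatic carbon of a six-membered aromatic ring of carbon only, meta to a large group (nitro in place of fluoro on an aromatic carbon).

Three measured steps change substituents on that same ring. They are a step that the two limits leave unreadable from compound 1 to compound 2 and a step that the two limits leave unreadable from compound 1 to compound 3 and finally a step that the two limits leave unreadable from compound 2 to compound 3 as the third. Among the compounds with values here, none of them has a readable size, and no compound in these steps gives a number. The data therefore offer no measured size to carry over, and no direction is favoured for the new group. No step beyond the scatter is expected in this assay on this evidence. The expected step is a step that the limit leaves unreadable from compound 1 to compound 4 and remains a weakly founded estimate. Compound 4 is estimated at 12000 nM with an expected range from 4000 nM to 40000 nM and will most likely be reported only as a limit again.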

Compound 4, half-maximal inhibitory concentration: > 10000 nM
Compound 4 was reported as a limit (the forecaster's own chance of this, stated with the estimate: 80%); the middle value is on the limit's open side.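

In this assay compound 4 gives > 10000 nM, a limit and not a number. No step from compound 1 to compound 4 can be read, because both compounds sit at the same limit: the limit of > 10000 nM in this assay, at which 4 of the 4 values shown sit.

The compounds shown leave open whether any substituent on this ring gives a measurable value in this assay.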